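The source may hold more compounds than are shown below. What is called first, only, known or untested is meant among the compounds shown, and "the series" means these compounds.

Measured in a functional assay on DU-145 cells (Homo sapiens) for cytotoxicity, read by trypan blue exclusion, with a stated time of 96 h; a higher number here means a weaker inhibitor, a lower number a stronger inhibitor:
- compound 1 `COc1cc(OC)c(/C=C/S(=O)(=O)Nc2ccc(OC)c(OP(=O)(O)O)c2)c(OC)c1`: 40 nM
- compound 2 `COC(=O)C(Nc1cc(NS(=O)(=O)/C=C/c2c(OC)cc(OC)cc2OC)ccc1OC)c1ccc(F)cc1`: 2500 nM

Of these two numbers, compound 2 holds the higher, which makes it the weaker inhibitor of the pair, and the gap to compound 1 lies beyond the scatter. The next compound to be tested is compound 3 `COc1cc(OC)c(/C=C/S(=O)(=O)Nc2ccc(OC)c(NCC(=O)O)c2)c(OC)c1`. It has carboxymethyl in place of (4-fluorophenyl)(methoxycarbonyl)methyl on a nitrogen on an aromatic ring. For the measured compounds named here, no step between measured compounds offers a direct guide to this change. Compound 1, which also lacks the aromatic ring that leaves, gives 40 nM in this assay, and the expectation rests on that value. A large move toward a lower number, beyond the scatter, is therefore expected, with an estimated step of a 42-fold lower number from compound 2 to compound 3 (1.62 log units; beyond the scatter). Compound 3 is estimated at 60 nM, within an expected range of 12 nM to 400 nM.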

Compound 3, half-maximal inhibitory concentration: 400 nM
Compound 3: middle estimate off by 6.7-fold (0.82 log units), on the low side, and the stated range covers the measured number.
By their numbers in this assay, from the lowest: compound 1; then compound 3; then compound 2.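

In this assay, carboxymethyl in place of (4-fluorophenyl)(methoxycarbonyl)methyl on a nitrogen on an aromatic ring gives a 6.3-fold lower number from compound 2 to compound 3 (0.80 log units; beyond the scatter) and so shows that this position tolerates loss of the aromatic ring and the ester, with a modest step beyond the scatter. The second comparison sets a limit on that recovery, as exchanging the phosphorus-containing group of 5 heavy atoms for the nitrogen-containing group of 5 heavy atoms on an aromatic carbon gives a 10-fold higher number from compound 1 to compound 3 (1.00 log units; beyond the scatter) and leaves the smaller nitrogen substituent short of the phosphorus-containing compound. Nothing measured here accounts for either step.

The compounds shown leave open whether the carboxylic acid itself matters or only the smaller size of the substituent. A methyl ester of the carboxymethyl group, an unsubstituted amine or a longer carboxyethyl chain on that nitrogen would separate these readings.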